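The compounds below may be only part of what the source reports. "The series", "measured", "known", "first", "only" and "open" are said of these compounds alone.

Compound 2, `COc1cc2c(Oc3ccc(NC(=O)c4nn(-c5ccc(Br)cc5)c(=O)c5ccccc45)cc3F)ccnc2cc1OCCCN1CCN(C)CC1`, gives 1370 nM in a functional assay on MDA-MB-231 cells (Homo sapiens) for cytotoxicity, read by MTT assay, with a stated time of 72 h; a higher number here means a weaker inhibitor, a lower number a stronger inhibitor.
Compound 1, `COc1cc2c(Oc3ccc(NC(=O)c4nn(-c5ccc([N+](=O)[O-])cc5)c(=O)c5ccccc45)cc3F)ccnc2cc1OCCCN1CCCC1`, gives 2980 nM in this assay.

Of the two measured compounds, compound 2 has the lower number and so is the stronger inhibitor, with compound 1 standing beyond the usual scatter above it. The two differ in more than one place, so no single change can be read from that gap.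

Compound 3, `COc1cc2c(Oc3ccc(NC(=O)c4nn(-c5ccc([N+](=O)[O-])cc5)c(=O)c5ccccc45)cc3F)ccnc2cc1OCCCN1CCN(C)CC1`, arises from compound 2 by one change: nitro in place of bromo on an aromatic carbon. Compound 1 carries the same nitro group on the same aromatic carbon, but with a different amine at the chain end, so it gives only a rough pointer.

For compound 3, a modest weakening relative to compound 2 is expected, short of the number of compound 1, as a 1.5-fold higher number from compound 2 to compound 3 (0.16 log units; within the scatter). The estimate for compound 3 is 2000 nM, expected to fall between 1000 nM and 4500 nM.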

Compound 3, half-maximal inhibitory concentration: 3490 nM
Beside the measured number, compound 3's estimate is 1.7-fold (0.24 log units) below it; low and high end bracket the measured number.
By their numbers in this assay, from the lowest: compound 2; then compounds 1 and 3 (each within the scatter of the next).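

Among the compounds shown here, replacing 4-bromophenyl with 4-nitrophenyl gives a 2.5-fold higher number from compound 2 to compound 3 (0.41 log units; beyond the scatter) in this assay and is the first clean reading at this position: the group on this ring changes the result, and the bromo compound is the stronger inhibitor of the pair. With nitro held in place, the amine at the chain end can also be read on its own: 4-methylpiperazin-1-yl in place of pyrrolidin-1-yl gives a 1.2-fold higher number from compound 1 to compound 3 (0.07 log units; within the scatter) and stays within the usual scatter. Nothing measured here explains the size of either step.

As far as these compounds go, it remains open whether the amine swap would read the same with bromo on the ring. From the compounds shown here alone, how a chlorine, a methoxy group or a nitrile would compare at this position, or a morpholine at the chain end, also remains unknown.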